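Cyclohexyl to methyl on the distal aryl ring

The source may hold more compounds than are shown below. What is called first, only, known or untested is meant among the compounds shown, and "the series" means these compounds.

Measured so far:
- compound 1 `CC#CC(CC(=O)O)c1ccc(OCc2ccc3nc(-c4ccc(F)cc4F)cn3c2)cc1`: 825 nM
- compound 2 `CC#CC(CC(=O)O)c1ccc(OCc2ccc3nc(-c4ccc(C5CCCCC5)cc4)cn3c2)cc1`: 417 nM

In an assay on isolated protein for agonist activity at Free fatty acid receptor 1 (Homo sapiens) (on this read-out higher numbers stand for an effect only at larger amounts of compound and lower numbers for an effect already at smaller amounts), compound 2 gives the lower of the two numbers, with compound 1 nearest at 825 nM; the gap between them, a 2.0-fold lower number from compound 1 to compound 2 (0.30 log units; within the scatter), stays within the scatter. Compound 3 `CC#CC(CC(=O)O)c1ccc(OCc2ccc3nc(-c4ccc(C)cc4)cn3c2)cc1` differs from compound 2 by methyl in place of cyclohexyl on an aromatic carbon, placed para to a large group. Within the data shown here, only one measured step touches this aryl ring, and it is a 2.0-fold lower number from compound 1 to compound 2 (0.30 log units; within the scatter), a swap of the whole ring rather than of its para substituent alone; nothing measured isolates cyclohexyl against methyl. Among the measured compounds shown here, with the single relevant step sitting within the scatter, the expected change for compound 3 is a 1.6-fold higher number from compound 2 to compound 3 (0.19 log units; within the scatter), no clear direction beyond the scatter. Compound 3 is therefore estimated at 650 nM in this assay, with a range of 250 nM to 1700 nM.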

Compound 3, half-maximal effective concentration: 507 nM
Estimate against measurement, compound 3: 1.3-fold (0.11 log units) above; the range from low to high includes it.
By their numbers in this assay, from the lowest: compounds 2, 3 and 1 (each within the scatter of the next).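

In this assay, among these compounds, methyl in place of cyclohexyl on the aromatic carbon gives a 1.2-fold higher number from compound 2 to compound 3 (0.08 log units; within the scatter) and is the first step to isolate this group from the rest of the aryl ring. The group can thus shrink from a six-membered ring of carbon to a single carbon without a change beyond the scatter. The second comparison, 4-methylphenyl in place of 2,4-difluorophenyl, gives a 1.6-fold lower number from compound 1 to compound 3 (0.21 log units; within the scatter) and also stays within the scatter, so the three aryl groups shown are not separated on this read-out, and no evidence available here bears on this result.

As far as these compounds go, whether an amine, a carboxylic acid or a longer alkyl chain on this carbon would move the number beyond the scatter remains open. Also open, from the compounds shown here alone, is how a plain phenyl ring, with hydrogen in place of methyl, compares with these three compounds.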